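A few compounds are considered here, and "the series" means these few. Any claim that something is new, unique, unknown or untested is made for them only; others in the source may bear on it.

Compound 1 `Cc1cc(Oc2ccc(Cl)cc2)c(S(C)(=O)=O)cc1C(=O)N=C(N)N` gives 13 nM in a functional assay for inhibition of sodium/hydrogen exchanger (Oryctolagus cuniculus); a lower number here means a stronger inhibitor, a higher number a weaker inhibitor.
Compound 2 `Cc1cc(-n2ccnc2C)c(S(C)(=O)=O)cc1C(=O)N=C(N)N` gives 29 nM in this assay.

Among the measured compounds shown here, compound 2 holds the higher of the two numbers; the single measured step in this assay is a 2.2-fold higher number from compound 1 to compound 2 (0.35 log units; beyond the scatter). Compound 3 `Cc1cc(Nc2ccccc2)c(S(C)(=O)=O)cc1C(=O)N=C(N)N` is not yet measured and differs from compound 2 by anilino in place of 2-methyl-1H-imidazol-1-yl on an aromatic carbon. For the measured compounds named here, only that one step bears on it, and it ran the opposite way, from a six-membered aromatic ring of carbon only to the imidazolyl group that now leaves. Anilino again carries a six-membered aromatic ring of carbon only, so a modest downward step is expected, a 1.9-fold lower number from compound 2 to compound 3 (0.29 log units; within the scatter), back toward compound 1. For compound 3 the estimate is 15 nM, range 6 nM to 40 nM.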

Compound 3, half-maximal inhibitory concentration: 21 nM
The estimate for compound 3 lay 1.4-fold (0.15 log units) below the measured number; measured number inside the range.
By their numbers in this assay, from the lowest: compounds 1, 3 and 2 (each within the scatter of the next, the first and the last beyond it).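

In this assay, anilino ortho to a methylsulfonyl group cannot be separated from either earlier group: the imidazolyl swap gives a 1.4-fold lower number from compound 2 to compound 3 (0.14 log units; within the scatter), and the 4-chlorophenoxy swap gives a 1.6-fold higher number from compound 1 to compound 3 (0.21 log units; within the scatter). Among the compounds shown here, the one step beyond the scatter therefore does not establish a divide between six-membered carbon rings and the imidazolyl group, as compound 3 lies within the scatter of both compounds. Whether a saturated amine such as piperidin-1-yl fits within this narrow span remains open, and no available evidence explains these numbers.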